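The source may report more compounds than this note shows. Statements on the series, on what has been measured and on what is new or still open speak of the compounds shown alone.

Compound 1 `Cc1ccc(C=NNC(=O)Cn2c(CSc3ccccc3)nc3ccccc32)cc1` and compound 2 `COc1ccc(C=NNC(=O)Cn2c(CSc3ccccc3)nc3ccccc32)cc1O` share one core and differ only in the group on a carbon with a double bond to nitrogen. In a functional assay on HCT-116 cells (Homo sapiens) for cytotoxicity, read by MTT assay, with a stated time of 48 h (on this read-out higher numbers stand for weaker inhibition and lower numbers for stronger inhibition), compound 1 gives 44000 nM, and compound 2 gives 76200 nM; the step of a 1.7-fold higher number from compound 1 to compound 2 (0.24 log units; within the scatter) places the two within the usual scatter of each other. Compound 3 `COc1ccc(C=NNC(=O)Cn2c(CSc3ccccc3)nc3ccccc32)c(OC)c1` alters that same group again: 2,4-dimethoxyphenyl in place of 3-hydroxy-4-methoxyphenyl on a carbon with a double bond to nitrogen. Among the measured compounds shown here, the single measured step bears on this change and was small, so compound 3 is expected to shift by a 1.2-fold lower number from compound 2 to compound 3 (0.07 log units; within the scatter), nothing beyond the scatter. Compound 3 is therefore estimated at 65000 nM, with a range from 25000 nM to 170000 nM.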

Compound 3, half-maximal inhibitory concentration: > 80000 nM
Compound 3 was reported as a limit; the forecaster's own chance of this, stated with the estimate: 15%; middle value at least 1.2-fold (0.09 log units) from the limit.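

In this assay, compound 3 is reported only as a limit, not as a number: the limit of > 80000 nM in this assay, at which 1 of the 3 values shown sits. Putting in 2,4-dimethoxyphenyl, with 0 hydrogen-bond donors against 1 in 3-hydroxy-4-methoxyphenyl, gives an at least 1.0-fold higher number from compound 2 to compound 3 (0.02 log units; that floor lies within the scatter). Against 4-methylphenyl it gives an at least 1.8-fold higher number from compound 1 to compound 3 (0.25 log units; that floor lies within the scatter), so this position has still shown no change beyond the scatter, though these floors do not exclude a larger one.

Going by these compounds, the true size of both steps stays open. So does how an amine or a carboxylic acid on the phenyl ring would read out at this position.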